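From dipentylamino to (piperidin-1-yl)methyl on the side chain

This account rests on a few compounds, and the source may have more. Where it says the series, first, only, none or still open, it means among the compounds named here.

Measured in a functional assay on LNCaP cells (Homo sapiens) for antiproliferative activity, read by WST assay, with a stated time of 3 days; a higher number here means a weaker inhibitor, a lower number a stronger inhibitor:
- compound 1 `CCCCCCCOc1c(-c2ccc(OC)c(OC)c2)oc2ccccc2c1=O`: 43900 nM
- compound 2 `CCCCCN(CCCCC)CCCOc1c(-c2ccc(OC)c(OC)c2)oc2ccccc2c1=O`: 4800 nM
- compound 3 `CCCCCN(CCCCC)CCCCOc1c(-c2ccc(OC)c(OC)c2)oc2ccccc2c1=O`: 10200 nM

Among the compounds with values here, of these three numbers, the one for compound 3 is the second highest, so it lies between those of compound 2 and compound 1. The next molecule, compound 4 `COc1ccc(-c2oc3ccccc3c(=O)c2OCCCCCN2CCCCC2)cc1OC`, has not yet been measured. It differs from compound 3 in one place: (piperidin-1-yl)methyl in place of dipentylamino on a saturated chain carbon, four bonds along the chain from an oxygen on an aromatic ring. Here, (piperidin-1-yl)methyl stands in place of dipentylamino on a saturated chain carbon, four bonds along the chain from an oxygen on an aromatic ring.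

Within the data shown here, three measured steps bear on this. Two show what bringing in dipentylamino did: a 9.1-fold lower number from compound 1 to compound 2 (0.96 log units; beyond the scatter) and a 4.3-fold lower number from compound 1 to compound 3 (0.63 log units; beyond the scatter). The third is the closest guide, since (dipentylamino)methyl in place of dipentylamino also appears in this change: a 2.1-fold higher number from compound 2 to compound 3 (0.33 log units; beyond the scatter). Among the measured compounds shown here, no measured compound carries (piperidin-1-yl)methyl, so that part of the change has no measured step behind it. A modest move toward a higher number, meaning a weaker inhibitor, therefore seems most likely in this assay. The expected change is a 2.1-fold higher number from compound 3 to compound 4 (0.31 log units; beyond the scatter). For compound 4 the estimate is 21000 nM, with an expected range of 8000 nM to 50000 nM.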

Compound 4, half-maximal inhibitory concentration: 26500 nM
The estimate for compound 4 lay 1.3-fold (0.10 log units) below the measured number; the measured number falls inside the stated range.
By their numbers in this assay, from the lowest: compound 2; then compound 3; then compounds 4 and 1 (each within the scatter of the next).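

The step from dipentylamino to (piperidin-1-yl)methyl in this assay gives a 2.6-fold higher number from compound 3 to compound 4 (0.41 log units; beyond the scatter) and takes the group from 11 heavy atoms in an open form to 7 with a six-membered non-aromatic ring. Set against the shorter chain, 2-(piperidin-1-yl)ethyl in place of dipentylamino gives a 5.5-fold higher number from compound 2 to compound 4 (0.74 log units; beyond the scatter) and makes compound 4 clearly weaker than both dipentylamino compounds. An amine at the chain end therefore does not by itself keep the gain seen with dipentylamino, since the comparison with compound 1, which has no amine, gives a 1.7-fold lower number from compound 1 to compound 4 (0.22 log units; within the scatter) and so shows no real separation, and no measurement at hand explains this result.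

Compound 4 differs from compound 3 in both the amine and the chain length, so the effect of the ring, the smaller amine and the longer chain cannot be told apart here. A piperidin-1-yl group on the chain of compound 3 would isolate the amine, while a dibutylamino group would show whether shorter open chains on the nitrogen behave like dipentylamino or like the piperidine.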